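Swapping Trifluoromethyl for Chloro on the Urea Aryl Ring

The source may hold more compounds than are shown below. What is called first, only, known or untested is meant among the compounds shown, and "the series" means these compounds.

Compound 2 `COc1cc2cc(Oc3ccc(NC(=O)Nc4ccc(Cl)c(C(F)(F)F)c4)cc3)c(C)nc2cc1OC` has the lowest of the two numbers in a functional assay on SR cells (Homo sapiens) for inhibition, read by sulforhodamine B assay, with a stated time of 48 h (a higher number here means a weaker inhibitor of growth, a lower number a stronger inhibitor of growth), giving 2650 nM. Compound 1 `COc1cc2cc(Oc3ccc(NC(=O)Nc4cccc(C(F)(F)F)c4)cc3)c(C)nc2cc1OC` gives 3330 nM in this assay, and the step of a 1.3-fold lower number from compound 1 to compound 2 (0.10 log units; within the scatter) lies within the scatter. Compound 3 `COc1cc2cc(Oc3ccc(NC(=O)Nc4ccc(Cl)c(Cl)c4)cc3)c(C)nc2cc1OC` differs from compound 2 by chloro in place of trifluoromethyl on an aromatic carbon. Within the data shown here, no measured step shows this exact exchange; the only step at hand, from compound 1 to compound 2, is the small one already given, so nothing argues for a change beyond the scatter. Compound 3 is therefore expected to give about 3000 nM in this assay, likely between 1200 nM and 7500 nM, which means an expected step of a 1.1-fold higher number from compound 2 to compound 3 (0.05 log units; within the scatter).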

Compound 3, concentration for total growth inhibition: 10300 nM
Beside the measured number, compound 3's estimate is 3.4-fold (0.54 log units) below it; the measured number lies above the stated range.
By their numbers in this assay, from the lowest: compounds 2 and 1 (each within the scatter of the next); then compound 3.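

Putting chloro in place of trifluoromethyl gives a 3.9-fold higher number from compound 2 to compound 3 (0.59 log units; beyond the scatter) in this assay, so this aromatic carbon responds to change, whereas the chloro added in compound 2 left the number within the scatter. The 3,4-dichlorophenyl group also compares poorly with the 3-(trifluoromethyl)phenyl group, with a 3.1-fold higher number from compound 1 to compound 3 (0.49 log units; beyond the scatter). Nothing at hand explains why this exchange raises the number. Going by these compounds, whether a methyl group, a nitrile or a methoxy group on this carbon would stay close to compound 2 remains open.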